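The source may report more compounds than this note shows. Statements on the series, on what has been measured and on what is new or still open speak of the compounds shown alone.

Measured so far:
- Compound 1, `O=C(O)CCc1ccc(OCc2ncc(-c3cccc(F)c3)o2)cc1`: 1070 nM
- Compound 2, `COc1cccc(-c2noc(COc3ccc(CCC(=O)O)cc3)n2)c1`: 2670 nM
- Compound 3, `CC(Oc1ccc(CCC(=O)O)cc1)c1nc(-c2ccc(Cl)cc2)no1`: 500 nM

These three compounds were tested in a functional assay on CHO cells for agonist activity at Free fatty acid receptor 1 (Homo sapiens), read by FLIPR and calcium flux, in the presence of a further agent that is not named here; a higher number here means that more compound is needed for the effect, a lower number that less compound is needed. Among the three numbers, compound 1 stands second highest: compound 3 is nearest to it with a lower number, and compound 2 is furthest with a higher number, both gaps lying beyond the usual scatter of repeated measurements.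

Compound 4, `O=C(O)CCc1ccc(OCc2ncc(-c3cccc(Cl)c3)o2)cc1`, has not yet been measured. It differs from compound 1 in a single place:

chloro in place of fluoro on an aromatic carbon

Among the compounds with values here, no pair of already measured compounds shows this exact exchange on a shared core, so there is no measured step to lean on. The change is small, swapping one halogen for another, and the expectation in this assay is a modest step toward a lower number, of a size that may not rise beyond the scatter, as expressed by a 1.6-fold lower number from compound 1 to compound 4 (0.22 log units; within the scatter). Compound 4 is therefore estimated at 650 nM, with a likely range from 250 nM to 1600 nM.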

Compound 4, half-maximal effective concentration: 47500 nM
The estimate for compound 4 lay 73-fold (1.86 log units) below the measured number; the measured number lies above the stated range.
By their numbers in this assay, from the lowest: compound 3; then compound 1; then compound 2; then compound 4.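

In this assay, chloro in place of fluoro on an aromatic carbon, meta to a large group, gives a 44-fold higher number from compound 1 to compound 4 (1.65 log units; beyond the scatter). Within the data shown here, this shows that the position is highly sensitive to which halogen it carries, something no earlier measured step could reveal. The exchange of one heavy atom for another, with no change in hydrogen-bond donors, hydrogen-bond acceptors or net charge, is enough to produce a large step, and no measurement at hand accounts for its size.

The compounds shown leave open whether bromo, methyl or plain hydrogen at this carbon would give a number close to that of compound 1 or close to that of compound 4. They also leave open whether the same exchange from fluoro to chloro would produce a step of similar size on a different core.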